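Shifting the Indole Attachment Point on Compound 2

The source may report more compounds than this note shows. Statements on the series, on what has been measured and on what is new or still open speak of the compounds shown alone.

Of the compounds shown here, two have so far been measured in a functional assay on HeLa cells (Homo sapiens) for antiproliferative activity, read by MTT assay, with a stated time of 48 h; on this read-out higher numbers stand for weaker inhibition and lower numbers for stronger inhibition. Compound 1 `COc1ccc(/C=C/C=C\c2cc(OC)c(OC)c(OC)c2)cc1O` gives 62 nM in this assay. Compound 2 `CCOc1cc(-c2ccc3cc[nH]c3c2)cn2c(-c3cc(OC)c(OC)c(OC)c3)nnc12` gives 272 nM in this assay, the highest of the two numbers; compound 1 stands nearest to it, and the gap between them lies beyond the scatter. Compound 3 `CCOc1cc(-c2ccc3[nH]ccc3c2)cn2c(-c3cc(OC)c(OC)c(OC)c3)nnc12` has the same atoms as compound 2, joined differently: 1H-indol-5-yl in place of 1H-indol-6-yl on an aromatic carbon. Among the measured compounds shown here, no measured pair in this set differs by a change of this kind, so the step from compound 2 to compound 3 in this assay has no measured anchor. The author expects the step of a 1.1-fold higher number from compound 2 to compound 3 (0.04 log units; within the scatter) to stay within the scatter, with no clear direction. On that basis compound 3 is estimated at 300 nM in this assay, with a range of 100 nM to 900 nM.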

Compound 3, half-maximal inhibitory concentration: 166 nM
The estimate for compound 3 lay 1.8-fold (0.26 log units) above the measured number, within the range that was stated.
By their numbers in this assay, from the lowest: compound 1; then compounds 3 and 2 (each within the scatter of the next).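

In this assay, 1H-indol-5-yl in place of 1H-indol-6-yl on the aromatic carbon gives a 1.6-fold lower number from compound 2 to compound 3 (0.21 log units; within the scatter), the first step measured at this position. Within the scatter of this read-out, the two attachment points of the indole cannot be told apart, so on this core and in these cells, the change of attachment shows no clear effect. Nothing measured here accounts for this result.

The compounds shown leave open whether the same holds for a third attachment point, such as 1H-indol-4-yl, or for a methyl group on the indole nitrogen. They also leave open how either indole would behave with a propoxy chain or an amine in place of the ethoxy group.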